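The source may report more compounds than this note shows. Statements on the series, on what has been measured and on what is new or still open speak of the compounds shown alone.

Compound 1 `CCN(Cc1ccccn1)c1cccc(C(=O)N2CCc3ccc(OS(N)(=O)=O)cc3C2)c1` carries an ethyl((pyridin-2-yl)methyl)amino group on its core. In an assay on HEK293 cells for inhibition of Steryl-sulfatase (Homo sapiens), tested at 0.1 uM (on this read-out lower numbers stand for a weaker effect and higher numbers for a stronger effect at the one concentration tested), compound 1 gives 6.5%. Among the compounds with values here, the one other compound measured alongside it, compound 2 `NS(=O)(=O)Oc1ccc2c(c1)CN(C(=O)c1cccc(N3CCN(c4ncccn4)CC3)c1)CC2`, gives 1.6% in this assay, and the two numbers lie within the usual scatter of each other, so compound 1 stands at the low end together with compound 2, with nothing separating them. Compound 3 `CCCN(Cc1ccccc1)c1cccc(C(=O)N2CCc3ccc(OS(N)(=O)=O)cc3C2)c1` has not yet been tested. It differs from compound 1 in one place: benzyl(propyl)amino in place of ethyl((pyridin-2-yl)methyl)amino on an aromatic carbon. Within the data shown here, no measured pair shows a change of this kind, so there is no step to lean on. Given that compound 1 gives 6.5%, compound 3 is expected to stay close to that value, with a number 1.5 percentage points higher from compound 1 to compound 3 (within the scatter) as the anticipated step, none beyond the scatter. Compound 3 is therefore estimated at 8% in this assay, within a range of 0% to 25%.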

Compound 3, a percentage reported as inhibition, at one concentration (the size of the read-out at that concentration, not a potency): 23.1%
For compound 3 the middle estimate is 15.1 percentage points below the measured one; low and high end bracket the measured number.
By their numbers in this assay, from the lowest: compounds 2 and 1 (each within the scatter of the next); then compound 3.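

Within the data shown here, the position carrying the amino group, on an aromatic carbon meta to a large group, is not indifferent in this assay: benzyl(propyl)amino in place of ethyl((pyridin-2-yl)methyl)amino gives a number 16.6 percentage points higher from compound 1 to compound 3 (beyond the scatter) and is the first single-place change seen here. The swap alters two things at once, the ring going from one with a hetero atom to one of carbon only and the ethyl chain giving way to propyl, so the step belongs to the whole change and not to either part. Nothing available accounts for the higher number.

From the compounds shown here alone, it remains open whether the ring or the chain carries the step, which benzyl(ethyl)amino would help to separate. A dipropylamino group would show whether an aromatic ring is needed on this nitrogen at all.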